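Triazole aryl group and antiproliferative activity on A549 cells

The source may report more compounds than this note shows. Statements on the series, on what has been measured and on what is new or still open speak of the compounds shown alone.

Compound 1 `Cc1cccc(-n2nncc2CN2C(=O)C3(C(C#N)=C(N)Oc4c(N)cc5nc6ccccc6nc5c43)c3ccccc32)c1` gives 12300 nM in a functional assay on A549 cells (Homo sapiens) for antiproliferative activity, read by MTT assay, with a stated time of 48 h; a lower number here means a stronger inhibitor, a higher number a weaker inhibitor.
Compound 2 `CC(=O)Nc1ccc(-n2nncc2CN2C(=O)C3(C(C#N)=C(N)Oc4c(N)cc5nc6ccccc6nc5c43)c3ccccc32)cc1` gives > 50000 nM in this assay, a limit of the assay rather than a number.
Compound 3 `CCc1cccc(C)c1-n1nncc1CN1C(=O)C2(C(C#N)=C(N)Oc3c(N)cc4nc5ccccc5nc4c32)c2ccccc21` gives > 50000 nM in this assay, likewise a limit of the assay.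

Compound 3 thus stands at the limit of the assay, and it shares this position with one other compound (the limit of > 50000 nM in this assay, at which 2 of the 3 values shown sit). The step from compound 1 to it is an at least 4.0-fold higher number from compound 1 to compound 3 (0.60 log units; beyond the scatter), and the step from compound 1 to compound 2 is an at least 4.0-fold higher number from compound 1 to compound 2 (0.60 log units; beyond the scatter). Between compound 2 and compound 3 the two limits leave the step unreadable a step that the two limits leave unreadable from compound 2 to compound 3.

Compound 4 `Cc1cc(C)cc(-n2nncc2CN2C(=O)C3(C(C#N)=C(N)Oc4c(N)cc5nc6ccccc6nc5c43)c3ccccc32)c1` differs from compound 3 by 3,5-dimethylphenyl in place of 2-ethyl-6-methylphenyl on an aromatic nitrogen. Going by the values given here, the only step that bears on it is the one from compound 1 to compound 3, where the 2-ethyl-6-methylphenyl group gave a weaker inhibitor than the 3-methylphenyl group. The 3,5-dimethylphenyl group of compound 4 is closer in its make-up to the 3-methylphenyl group of compound 1 than to the 2-ethyl-6-methylphenyl group of compound 3. Compound 4 is therefore expected to lie between compound 1 and the limit, with the step from compound 3 to compound 4 estimated as an at least 2.2-fold lower number from compound 3 to compound 4 (0.35 log units; beyond the scatter). The estimate for compound 4 in this assay is 22000 nM, within a range from 8000 nM to 60000 nM.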

Compound 4, half-maximal inhibitory concentration: 31200 nM
For compound 4 the middle estimate is 1.4-fold (0.15 log units) below the measured one, within the range that was stated.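

Adding a methyl on an aromatic carbon of the aryl group gives a 2.5-fold higher number from compound 1 to compound 4 (0.40 log units; beyond the scatter), the first step at this position with a measured number at both ends, so its size can be read rather than only a floor; compound 1, with its 3-methylphenyl group, remains the strongest of the four. Compound 2 and compound 3 carry limits of the assay rather than numbers, and the steps to compound 4 are an at least 1.6-fold lower number from compound 3 to compound 4 (0.20 log units; that floor lies within the scatter) and an at least 1.6-fold lower number from compound 2 to compound 4 (0.20 log units; that floor lies within the scatter), so neither step shows on its own that compound 4 is the stronger inhibitor. Compound 4 nevertheless has a measured number, whereas the 4-acetamidophenyl and 2-ethyl-6-methylphenyl groups are known only through the limit: the limit of > 50000 nM in this assay, at which 2 of the 4 values shown sit.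

The compounds shown leave open how an unsubstituted phenyl group on the aromatic nitrogen would compare with compound 1, and whether a methoxy group or an amine in place of the methyl of compound 1 would lower its number. They also leave open how far the true values of compound 2 and compound 3 lie beyond their limits.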